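Replacing a Methoxyphenyl with a Fluorohydroxyphenyl

This account rests on a few compounds, and the source may have more. Where it says the series, first, only, none or still open, it means among the compounds named here.

compound 1 `COc1ccc(/C=C/C(=O)c2ccc(N)c(-c3ccc(F)cc3)c2)cc1O` – "not determined" (no result reported)
compound 2 `COc1ccc(/C=C/C(=O)c2ccc(N)c(-c3ccc(F)cc3)c2)cc1` – 7230 nM

Within the data shown here, in a functional assay on SW480 cells (Homo sapiens) for cytotoxicity, read by sulforhodamine B assay, with a stated time of 48 h (a lower number here means a stronger inhibitor, a higher number a weaker inhibitor), compound 2 gives 7230 nM and this is the only number available, so it cannot be ranked against anything. Compound 3 `Nc1ccc(C(=O)/C=C/c2ccc(O)c(F)c2)cc1-c1ccc(F)cc1` departs from compound 2 as follows: 3-fluoro-4-hydroxyphenyl in place of 4-methoxyphenyl on a double-bonded chain carbon bound to a double-bonded chain carbon and so carries 3-fluoro-4-hydroxyphenyl in place of 4-methoxyphenyl on a double-bonded chain carbon bound to a double-bonded chain carbon. Among the measured compounds shown here, no measured step guides this change, so only a small shift toward stronger inhibition in this assay is expected, not clearly beyond the scatter, and a 1.4-fold lower number from compound 2 to compound 3 (0.16 log units; within the scatter) is the estimated step here. The expected value for compound 3 is 5000 nM with an estimated range from 1500 nM to 15000 nM in this measurement.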

Compound 3, half-maximal inhibitory concentration: 31700 nM
For compound 3 the middle estimate is 6.3-fold (0.80 log units) below the measured one, and the stated range ends below it.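

In this assay, putting 3-fluoro-4-hydroxyphenyl in place of 4-methoxyphenyl on a double-bonded chain carbon bound to a double-bonded chain carbon gives a 4.4-fold higher number from compound 2 to compound 3 (0.64 log units; beyond the scatter). This shows that inhibition responds to the group held at this position, and that this change weakens it. No measured evidence accounts for the shift. Because the fluorine and the hydroxyl enter together, the compounds shown leave open which of them goes with the loss. A 4-hydroxyphenyl or a 3-fluoro-4-methoxyphenyl group at this position would separate the two.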